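Lengthening the hydroxycarbamoyl chain of compound 3

This account rests on a few compounds, and the source may have more. Where it says the series, first, only, none or still open, it means among the compounds named here.

In a functional assay on SNU-423 cells (Homo sapiens) for inhibition, read by MTT assay, with a stated time of 72 h (a higher number here means a weaker inhibitor, a lower number a stronger inhibitor), compound 1 `Nc1ncnc2c1c(-c1cnc3[nH]ccc3c1)nn2CCCCCCCCC(=O)NO` gives 7500 nM and compound 2 `Nc1ncnc2c1c(-c1cnc3[nH]ccc3c1)nn2CCCCCCC(=O)NO` gives 7500 nM as well. Compound 3 `Nc1nc2cc(-c3nn(CCCCC(=O)NO)c4ncnc(N)c34)ccc2o1` gives 3030 nM and holds the lowest of the three numbers, which makes it the strongest inhibitor so far, beyond the scatter of both others.

Compound 4 `Nc1nc2cc(-c3nn(CCCCCCCCC(=O)NO)c4ncnc(N)c34)ccc2o1` keeps the rest of compound 3 and alters the chain alone, with 4-(hydroxycarbamoyl)butyl in place of hydroxycarbamoyl on a saturated chain carbon, four bonds along the chain from an aromatic nitrogen as the counted difference. In words, 4-(hydroxycarbamoyl)butyl stands in place of hydroxycarbamoyl on a saturated chain carbon, four bonds along the chain from an aromatic nitrogen.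

Within the data shown here, only one measured step bears on this, namely no change at the digits printed from compound 1 to compound 2 (within the scatter) on a chain of a different length. It runs the opposite way, with hydroxycarbamoyl in place of 2-(hydroxycarbamoyl)ethyl, and it is a smaller change than the one at hand. Among the measured compounds shown here, it also comes from compounds that differ from compound 3 elsewhere on the shared core, and no chain step has been measured with the group that compound 3 carries. No step beyond the scatter is therefore expected in this assay, though with wide uncertainty in either direction. The estimated step is a 1.0-fold lower number from compound 3 to compound 4 (0.00 log units; within the scatter) and nothing larger is expected. Compound 4 is expected at 3000 nM with an estimated range from 1000 nM to 8000 nM in this measurement.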

Compound 4, half-maximal inhibitory concentration: 4940 nM
Compound 4: middle estimate off by 1.6-fold (0.22 log units), on the low side, and the stated range covers the measured number.
By their numbers in this assay, from the lowest: compounds 3, 4, 1 and 2 (each within the scatter of the next, the first and the last beyond it).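

In this assay, the only chain step shown with the group that compound 3 carries reads a 1.6-fold higher number from compound 3 to compound 4 (0.21 log units; within the scatter) and so does not separate 4-(hydroxycarbamoyl)butyl from hydroxycarbamoyl at this position, on a saturated chain carbon, four bonds along the chain from an aromatic nitrogen. Compound 4 also gives a matched comparison of the two aromatic groups on the same chain, which reads a 1.5-fold lower number from compound 1 to compound 4 (0.18 log units; within the scatter) and so does not separate them at this chain length in this assay either. Nothing shown gives a reason for either reading.

The compounds shown leave open whether a longer chain still, or a carboxylic acid in place of the hydroxycarbamoyl end, would give a step beyond the scatter in this assay with the group that compound 3 carries. They also leave open whether the aromatic group of compound 1 would read the same on the shorter chain of compound 3, where only the group of compound 3 appears.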